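A few compounds are considered here, and "the series" means these few. Any claim that something is new, unique, unknown or untested is made for them only; others in the source may bear on it.

Compound 1 `O=C(O)Cn1c(SCCCOc2ccccc2)nc2ccccc21`: 786 nM
Compound 2 `O=C(O)Cn1c(SCCCCOc2ccccc2)nc2ccccc21`: 1400 nM
Compound 3 `O=C(O)Cn1c(SCCNc2ccccc2)nc2ccccc21`: 7690 nM

In an assay on HEK293 cells for displacement of a labelled ligand from prostaglandin D2 receptor 2 (Homo sapiens) (a lower number here means a stronger inhibitor, a higher number a weaker inhibitor), compound 2 stands second highest of the three numbers; its nearest neighbour is compound 1, a gap within the scatter, and its furthest is compound 3, a gap beyond it. Compound 4 `CCOC(=O)CCCCCSc1nc2ccccc2n1CC(=O)O` differs from compound 2 by (ethoxycarbonyl)methyl in place of phenoxy on a saturated chain carbon, four bonds along the chain from a sulfur. Within the data shown here, no measured step removes the aromatic ring altogether. The step of a 1.8-fold higher number from compound 1 to compound 2 (0.25 log units; within the scatter) shows that one more chain carbon changes little, whereas a 9.8-fold higher number from compound 1 to compound 3 (0.99 log units; beyond the scatter) shows that altering the link to the phenyl ring already costs a modest amount. A step in the weakening direction, beyond the scatter, is therefore expected, a 3.2-fold higher number from compound 2 to compound 4 (0.51 log units; beyond the scatter). Compound 4 is estimated at 4500 nM, in the range 1500 nM to 13000 nM.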

Compound 4, half-maximal inhibitory concentration: 1010 nM
For compound 4 the middle estimate is 4.5-fold (0.65 log units) above the measured one; measured number below the stated range.
By their numbers in this assay, from the lowest: compounds 1, 4 and 2 (each within the scatter of the next); then compound 3.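

In this assay, an aromatic ring at this chain end proves dispensable: with (ethoxycarbonyl)methyl in place of phenoxy, four bonds along the chain from a sulfur, the result is a 1.4-fold lower number from compound 2 to compound 4 (0.14 log units; within the scatter), and the comparison with the shorter phenoxy chain gives a 1.3-fold higher number from compound 1 to compound 4 (0.11 log units; within the scatter). The ester chain also differs clearly from the anilino chain, at a 7.6-fold lower number from compound 3 to compound 4 (0.88 log units; beyond the scatter), so leaving phenoxy behind does not by itself bring the loss seen with the anilino link. Nothing measured here explains this tolerance. The compounds shown leave open how a carboxylic acid or an amide at that chain end, or a longer chain carrying the ester, would fare.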